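Thiazolyl ethoxy replacement in a cytotoxicity series

The compounds below may be only part of what the source reports. "The series", "measured", "known", "first", "only" and "open" are said of these compounds alone.

Measured so far:
- compound 1 `Cc1ccc(CCOc2ccc(-c3c(C)nc(C)c([C@H](OC(C)(C)C)C(=O)O)c3N3CCC(C)(C)CC3)cc2)cc1`: in a toxicity assay on MT2 cells (Homo sapiens) for cytotoxicity, read by XTT assay, with a stated time of 4 days (on this read-out higher numbers stand for lower toxicity in this test and lower numbers for higher toxicity in this test), compound 1 gives >= 33500 nM, which is a limit of the test rather than a number.
- compound 2 `Cc1nc(C)c([C@H](OC(C)(C)C)C(=O)O)c(N2CCC(C)(C)CC2)c1-c1ccc(OCCc2ccc(Cl)cc2)cc1`: compound 2 gives >= 33500 nM, again a limit.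
- compound 3 `Cc1nc(C)c([C@H](OC(C)(C)C)C(=O)O)c(N2CCC(C)(C)CC2)c1-c1ccc(OCCc2ccncc2)cc1`: compound 3 gives >= 25000 nM, again a limit.

For the measured compounds named here, compound 2 therefore stands only at a limit, and the two further values shown are limits as well, so no compound can be placed above or below another. The three measured steps, a step that the two limits leave unreadable from compound 1 to compound 2, a step that the two limits leave unreadable from compound 1 to compound 3 and a step that the two limits leave unreadable from compound 2 to compound 3, are all unreadable in size; the evidence behind them is the limit of >= 33500 nM in this assay, at which 2 of the 3 values shown sit, and (the limit of >= 25000 nM in this assay, at which 1 of the 3 values shown sits).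

The unmeasured compound 4 `Cc1nc(C)c(CCOc2ccc(-c3c(C)nc(C)c([C@H](OC(C)(C)C)C(=O)O)c3N3CCC(C)(C)CC3)cc2)s1` differs from compound 2 by 2,4-dimethyl-1,3-thiazol-5-yl in place of 4-chlorophenyl on a saturated chain carbon, two bonds along the chain from an oxygen on an aromatic ring. All measured steps that bear on this position are unreadable, so in this assay no step beyond the scatter is expected in either direction, and the step that the limit leaves unreadable from compound 2 to compound 4 is expected to be nil. Compound 4 is estimated at 50000 nM, with a range of 25000 nM to 150000 nM, most likely reported as a limit.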

Compound 4, half-maximal cytotoxic concentration: >= 25000 nM
Compound 4: a limit, no number; the forecaster's own chance of this, stated with the estimate: 80%; the middle value lies beyond the limit too.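

Compound 4 gives >= 25000 nM in this assay, which is a limit. Its steps to compound 1, compound 2 and compound 3 therefore cannot be read. The compounds shown leave open where the half-maximal cytotoxic concentration of any of them lies, and whether the groups exchanged on the ethoxy chain differ at all.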